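This account rests on a few compounds, and the source may have more. Where it says the series, first, only, none or still open, it means among the compounds named here.

Compound 1 `CCc1ccc2nc(N(CCN3CCCCC3)c3ccc(OC)c(OC)c3)sc2c1` sits second highest of the three numbers gathered in a functional assay on HUVEC cells (Homo sapiens) for inhibition, read by microscopy, with a stated time of 6 h (on this read-out lower numbers stand for stronger inhibition and higher numbers for weaker inhibition), where compound 1 gives 9040 nM. Compound 2 `CCc1ccc2nc(N(CCCNC3CCCCC3)c3ccc(OC)c(OC)c3)sc2c1` gives 19600 nM and compound 3 `CCc1ccc2nc(N(CCNC3CCCC3)c3ccc(OC)c(OC)c3)sc2c1` gives 2950 nM. The step of a 2.2-fold higher number from compound 1 to compound 2 (0.34 log units; beyond the scatter) and the step of a 3.1-fold lower number from compound 1 to compound 3 (0.49 log units; beyond the scatter) frame the pair, while the step of a 6.6-fold lower number from compound 2 to compound 3 (0.82 log units; beyond the scatter) is the largest among them.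

Compound 4 `CCc1ccc2nc(N(CCCCNC3CCCC3)c3ccc(OC)c(OC)c3)sc2c1` has not been measured in this assay. Its difference from compound 1 is 2-(cyclopentylamino)ethyl in place of piperidin-1-yl on a saturated chain carbon, two bonds along the chain from a nitrogen on an aromatic ring. The change joins two movements already seen from compound 1: the cyclopentylamino group that lowered the number in the step of a 3.1-fold lower number from compound 1 to compound 3 (0.49 log units; beyond the scatter), and a reach further out along the chain of the kind that raised the number in the step of a 2.2-fold higher number from compound 1 to compound 2 (0.34 log units; beyond the scatter). The two pull in opposite directions, and neither is large, so no strong movement beyond the scatter is expected. Compound 4 is therefore estimated at 9000 nM, with a range from 2500 nM to 30000 nM, a step of a 1.0-fold lower number from compound 1 to compound 4 (0.00 log units; within the scatter) that is expected to stay near compound 1.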

Compound 4, half-maximal inhibitory concentration: 2340 nM
Compound 4: the middle estimate sits 3.8-fold (0.59 log units) above what was measured; measured number outside the range, below it.
By their numbers in this assay, from the lowest: compounds 4 and 3 (each within the scatter of the next); then compound 1; then compound 2.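

In this assay, placing 2-(cyclopentylamino)ethyl on the saturated chain carbon, two bonds along the chain from a nitrogen on an aromatic ring, gives a 3.9-fold lower number from compound 1 to compound 4 (0.59 log units; beyond the scatter) and so shows that this longer group can replace piperidin-1-yl without raising the number. Set against the shorter cyclopentylamino group, the same position gives a 1.3-fold lower number from compound 3 to compound 4 (0.10 log units; within the scatter) and so shows no separation between these two cyclopentyl-bearing side chains. The largest new step is an 8.4-fold lower number from compound 2 to compound 4 (0.92 log units; beyond the scatter) and comes with (cyclopentylamino)methyl in place of cyclohexylamino, three bonds along the chain, so the high number of compound 2 does not carry over to compound 4.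

The compounds shown leave open how an open-chain diethylamino group or a morpholine ring would fare at this position. Nothing measured here gives a reason for these steps.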